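Swapping chloro for methyl on the sulfonyl ring

This account rests on a few compounds, and the source may have more. Where it says the series, first, only, none or still open, it means among the compounds named here.

Compound 1 `Cc1cccc(-c2noc(C3CN(S(=O)(=O)c4cccc(C)c4)C3)n2)c1`: 650 nM
Compound 2 `Cc1ccc(S(=O)(=O)N2CC(c3nc(-c4cccc(Cl)c4)no3)C2)cc1`: 920 nM
Compound 3 `Cc1cccc(-c2noc(C3CN(S(=O)(=O)c4ccc(Cl)cc4)C3)n2)c1`: 1100 nM

In an assay on HEK293 cells for negative allosteric modulation of metabotropic glutamate receptor 5 (Homo sapiens), read by FLIPR (a higher number here means a weaker inhibitor, a lower number a stronger inhibitor), compound 3 gives the highest of the three numbers, but its gaps to compound 2 and compound 1 both fall within the scatter, so no ordering can be claimed. Compound 4 `Cc1ccc(S(=O)(=O)N2CC(c3nc(-c4cccc(C)c4)no3)C2)cc1` is compound 3 with methyl in place of chloro on an aromatic carbon. Among the measured compounds shown here, the one measured step that touches this part of the molecule, a 1.7-fold higher number from compound 1 to compound 3 (0.23 log units; within the scatter), was itself within the scatter. Compound 2, which carries the same 4-methylphenyl on its sulfonyl sulfur, shows a value close to that of compound 3. The step of a 1.3-fold lower number from compound 3 to compound 4 (0.11 log units; within the scatter) is therefore expected to be small, with no direction beyond the scatter. Compound 4 is estimated at 850 nM, within 400 nM to 1800 nM.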

Compound 4, half-maximal inhibitory concentration: 670 nM
The estimate for compound 4 lay 1.3-fold (0.10 log units) above the measured number, within the range that was stated.
By their numbers in this assay, from the lowest: compounds 1, 4, 2 and 3 (each within the scatter of the next).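

Exchanging 4-chlorophenyl for 4-methylphenyl on the sulfonyl sulfur now has a direct reading (a 1.6-fold lower number from compound 3 to compound 4 (0.22 log units; within the scatter)), so chloro and methyl at this position cannot be told apart. The same exchange on the other aromatic ring reads alike (a 1.4-fold lower number from compound 2 to compound 4 (0.14 log units; within the scatter)). Placing the sulfonyl ring's methyl as 4-methylphenyl rather than 3-methylphenyl also leaves the two compounds indistinguishable (a 1.0-fold higher number from compound 1 to compound 4 (0.01 log units; within the scatter)).

No measurement offers an explanation for these results. As far as these compounds go, whether an amine, a carboxylic acid or a methoxy group on the sulfonyl ring would shift the number beyond the scatter remains open.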